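The source may report more compounds than this note shows. Statements on the series, on what has been measured and on what is new or still open speak of the compounds shown alone.

Three analogues of the shared core have numbers in a functional assay for inhibition of sodium/hydrogen exchanger (Oryctolagus cuniculus); on this read-out lower numbers stand for stronger inhibition and higher numbers for weaker inhibition. Compound 1 `Cc1cc(Cl)c(S(C)(=O)=O)cc1C(=O)N=C(N)N` gives 25 nM, compound 2 `Cc1cc(Br)c(S(C)(=O)=O)cc1C(=O)N=C(N)N` gives 12 nM, and compound 3 `CCc1cc(Br)c(S(C)(=O)=O)cc1C(=O)N=C(N)N` gives 41 nM. Compound 2 holds the lowest number of the three, with both steps to its neighbours beyond the scatter: a 2.1-fold lower number from compound 1 to compound 2 (0.32 log units; beyond the scatter), and a 3.4-fold higher number from compound 2 to compound 3 (0.53 log units; beyond the scatter).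

The step from compound 2 to compound 4 `CCc1cc(C)c(C(=O)N=C(N)N)cc1S(C)(=O)=O` is ethyl in place of bromo on an aromatic carbon. Within the data shown here, two measured steps bear on it, but neither swaps a halogen for an alkyl chain. a 2.1-fold lower number from compound 1 to compound 2 (0.32 log units; beyond the scatter) shows a modest gain on going to the heavier halogen on this aromatic carbon. a 3.4-fold higher number from compound 2 to compound 3 (0.53 log units; beyond the scatter) shows a modest cost on going from methyl to ethyl on a saturated chain carbon bound to an aromatic carbon, a different place on the core. Among the measured compounds shown here, the group entering in compound 4 brings two carbons where bromo brought one bromine, and no measured pair covers such an exchange, so the direction is not fixed by the data; a modest rise in number, of about the size seen with compound 3, is the working expectation. The expected step in this assay is therefore a 2.5-fold higher number from compound 2 to compound 4 (0.40 log units; beyond the scatter). The estimate for compound 4 is 30 nM, with a range of 8 nM to 120 nM.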

Compound 4, half-maximal inhibitory concentration: 4.8 nM
Beside the measured number, compound 4's estimate is 6.3-fold (0.80 log units) above it, outside the stated range (below it).
By their numbers in this assay, from the lowest: compound 4; then compound 2; then compounds 1 and 3 (each within the scatter of the next).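

In this assay, a halogen is not needed on this aromatic carbon, ortho to a methylsulfonyl group: ethyl in place of bromo gives a 2.5-fold lower number from compound 2 to compound 4 (0.40 log units; beyond the scatter), and ethyl in place of chloro gives a 5.2-fold lower number from compound 1 to compound 4 (0.72 log units; beyond the scatter), which leaves ethyl with the lowest number of the three groups seen here. Read with a 2.1-fold lower number from compound 1 to compound 2 (0.32 log units; beyond the scatter), the numbers at this position fall from chloro to bromo to ethyl, while a 3.4-fold higher number from compound 2 to compound 3 (0.53 log units; beyond the scatter) runs the other way when a carbon is added to the methyl group elsewhere on the core, so the effect of an ethyl group on these compounds depends on where it stands. Nothing available accounts for the fall in number on going to ethyl at this position.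

The compounds shown leave open whether a longer chain such as propyl, or a branched group such as isopropyl, would lower the number further at this position or reverse the trend. They also leave open how an atom other than carbon or halogen would fare on this aromatic carbon, as in a methoxy group or an amine.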